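From dimethylamino to (pyrrolidin-1-yl)methyl on an inactive compound

The source may hold more compounds than are shown below. What is called first, only, known or untested is meant among the compounds shown, and "the series" means these compounds.

Within the data shown here, in a functional assay on A549 cells (Homo sapiens) for antiproliferative activity, read by MTT assay, with a stated time of 72 h (a lower number here means a stronger inhibitor, a higher number a weaker inhibitor), compound 1 (`N#Cc1ccc(/C=N/NC(=O)Nc2ccc(Oc3ccnc4[nH]ccc34)c(F)c2)cc1`) gives 1360 nM, the only actual number in this small set. Compound 2 (`CN(C)CCn1cccc1/C=N/NC(=O)Nc1ccc(Oc2ccnc3[nH]ccc23)c(F)c1`) has no number to its name and is recorded as "not active" (no number reported). Compound 3 (`CN(C)CCn1cccc1/C=N/NC(=O)Nc1ccc(Oc2ccnc3[nH]ccc23)cc1`) is likewise recorded as "not active" (no number reported).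

Compound 4 (`O=C(N/N=C/c1cccn1CCCN1CCCC1)Nc1ccc(Oc2ccnc3[nH]ccc23)c(F)c1`) keeps the rest of compound 2 and alters the end of one side chain: (pyrrolidin-1-yl)methyl in place of dimethylamino on a saturated chain carbon, two bonds along the chain from an aromatic nitrogen. In words, (pyrrolidin-1-yl)methyl takes the place of dimethylamino on a saturated chain carbon, two bonds along the chain from an aromatic nitrogen. Cut one bond further out, the same change reads 2-(dimethylamino)ethyl to 3-(pyrrolidin-1-yl)propyl.

Among the measured compounds shown here, no measured pair shows what this kind of change does, and compound 2 offers no number to step from. The expectation in this assay is therefore no clear gain: compound 4 may well be reported without a number too. The closest relatives point that way, with compound 2 at "not active" (no number reported) and compound 3 at "not active" (no number reported). If a number does appear, it is expected to lie on the weak side of compound 1, which gives 1360 nM. For compound 4, the estimated half-maximal inhibitory concentration is 6000 nM, with an expected range of 1500 nM to 25000 nM.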

Compound 4, half-maximal inhibitory concentration: 2010 nM
Compound 4: middle estimate off by 3.0-fold (0.47 log units), on the high side, within the range that was stated.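

No step can be read from compound 2 to compound 4: compound 2 is recorded in this assay as "not active", with no number to compare. The compounds shown leave open how much 3-(pyrrolidin-1-yl)propyl changes activity compared with 2-(dimethylamino)ethyl. No measurement here helps to explain the result.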